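Replacing a Diethylamide with a Cyclobutylmethyl Ester

This account rests on a few compounds, and the source may have more. Where it says the series, first, only, none or still open, it means among the compounds named here.

Of the compounds shown here, three share one core and have been tested in an assay on membranes from CHO cells for displacement of a labelled ligand from adenosine receptor A1 (Homo sapiens), read by scintillation counting, with a stated time of 60 min, tested at 1 uM; a higher number here means more inhibition at the concentration tested (going by the name of the read-out), a lower number less inhibition. Compound 1 `CCCC(=O)C1=C(C)NC(=O)NC1c1ccoc1` gives 1%. Compound 2 `CCN(CC)C(=O)C1=C(C)NC(=O)NC1c1ccoc1` gives 15%, and compound 3 `CCN(CC)C(=O)C1=C(C)NC(=O)NC1c1cccs1` gives 13%. Compound 2 therefore holds the highest of the three numbers, but its gap to compound 3 lies within the scatter, so the two cannot be ranked; only the difference from compound 1 is meaningful, as a number 14 percentage points higher from compound 1 to compound 2 (beyond the scatter) shows.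

Compound 4 `CC1=C(C(=O)OCC2CCC2)C(c2ccoc2)NC(=O)N1` has not yet been measured. It differs from compound 2 in one place: cyclobutylmethoxy in place of diethylamino on a carbonyl carbon. Within the data shown here, the one earlier step at the same carbonyl carbon, a number 14 percentage points higher from compound 1 to compound 2 (beyond the scatter), shows that changing the group on this carbon can shift the number modestly, while the ring swap in a number 2 percentage points lower from compound 2 to compound 3 (within the scatter) did not. Among the measured compounds shown here, the new ester group has no measured precedent. A modest fall is nonetheless expected, with the step of a number 8 percentage points lower from compound 2 to compound 4 (within the scatter). Compound 4 is thus estimated at 7%, between 0% and 20%.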

Compound 4, a percentage reported as inhibition, at one concentration (the size of the read-out at that concentration, not a potency): 46%
The estimate for compound 4 lay 39 percentage points below the measured number; measured number above the stated range.
By their numbers in this assay, from the lowest: compound 1; then compounds 3 and 2 (each within the scatter of the next); then compound 4.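

Among these compounds, at this carbonyl carbon, the group can matter much more than the earlier compounds showed: in this assay the cyclobutylmethoxy group gives a number 31 percentage points higher from compound 2 to compound 4 (beyond the scatter) and also a number 45 percentage points higher from compound 1 to compound 4 (beyond the scatter) as a second large step, whereas the only earlier change here was a number 14 percentage points higher from compound 1 to compound 2 (beyond the scatter) and modest. The shift from diethylamino to cyclobutylmethoxy adds a four-membered carbon ring and one hydrogen-bond acceptor, but these counts alone do not show which feature matters. No evidence is available to explain the rise.

Going by these compounds, it remains open whether the gain comes from the ester link or from the cyclobutyl ring, which a simple methyl ester or a cyclobutylmethyl amide at this carbon could help separate. On these data alone, it is also open whether the same gain would appear with thiophen-2-yl in place of furan-3-yl.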